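The source may report more compounds than this note shows. Statements on the series, on what has been measured and on what is new or still open speak of the compounds shown alone.

Measured so far:
compound 1, `CCCS(=O)(=O)Nc1cccc2c1CCCC2c1c[nH]cn1`: < 10000 nM
compound 2, `CCS(=O)(=O)Nc1cccc(-c2c[nH]cn2)c1`: < 10000 nM

In an assay on isolated protein (Cricetulus griseus) for binding affinity to Alpha-1B adrenergic receptor (Mesocricetus auratus), read by radioligand binding (a higher number here means a weaker inhibitor, a lower number a stronger inhibitor), compound 1 gives < 10000 nM, which is a limit of the assay and not a number. Compound 2 gives < 10000 nM, likewise a limit. Both values sit at the limit of < 10000 nM in this assay, at which 2 of the 2 values shown sit, so compound 1 stands at that limit and nowhere more exactly. Compound 3, `CN(c1cccc2c1CCCC2c1c[nH]cn1)S(C)(=O)=O`, differs from compound 1 by methyl(methylsulfonyl)amino in place of (propylsulfonyl)amino on an aromatic carbon. Among the measured compounds shown here, no measured step exists to set a direction; the step that the limit leaves unreadable from compound 1 to compound 3 is expected to stay within the usual scatter. Compound 3 is estimated at 1500 nM, between 150 nM and 9000 nM.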

Compound 3, inhibition constant: < 10000 nM
Compound 3: no number, only a limit; the forecaster's own chance of this, stated with the estimate: 40%; the middle value is on the limit's open side.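

No step can be read from compound 1 to compound 3 in this assay, as both values are limits and not numbers. The compounds shown leave open whether methyl(methylsulfonyl)amino and (propylsulfonyl)amino differ at all in this assay: the limit of < 10000 nM in this assay, at which 3 of the 3 values shown sit.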